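From propyl to butyl on compound 2

A few compounds are considered here, and "the series" means these few. Any claim that something is new, unique, unknown or untested is made for them only; others in the source may bear on it.

Of the compounds shown here, three sharing one core have been measured in a functional assay on MCF7 cells (Homo sapiens) for antiproliferative activity, read by sulforhodamine B assay, with a stated time of 48 h (a higher number here means a weaker inhibitor, a lower number a stronger inhibitor), and they differ only in the phenyl group on an oxygen. Compound 1 (`CCCN1CCN(c2ccc(S(=O)(=O)Oc3ccccc3C)cc2)C1=O`), carrying 2-methylphenyl, gives > 100000 nM, which is a limit of the assay and not a number. Compound 2 (`CCCN1CCN(c2ccc(S(=O)(=O)Oc3cccc(F)c3)cc2)C1=O`), carrying 3-fluorophenyl, gives 24000 nM, and compound 3 (`CCCN1CCN(c2ccc(S(=O)(=O)Oc3ccc(Cl)cc3)cc2)C1=O`), carrying 4-chlorophenyl, gives 18000 nM. These two stand close together, with a 1.3-fold lower number from compound 2 to compound 3 (0.12 log units; within the scatter). Both stand apart from compound 1, with an at least 4.1-fold lower number from compound 1 to compound 2 (0.61 log units; beyond the scatter) and an at least 5.5-fold lower number from compound 1 to compound 3 (0.74 log units; beyond the scatter).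

Compound 4 (`CCCCN1CCN(c2ccc(S(=O)(=O)Oc3cccc(F)c3)cc2)C1=O`) keeps the 3-fluorophenyl group of compound 2 and turns the propyl chain into butyl: methyl in place of hydrogen on a saturated chain carbon, three bonds along the chain from an amide-type nitrogen in a ring. Among the compounds with values here, none of the measured steps touches this chain, since all of them change the group on the oxygen, so they give no direct guide to the size of this change. Within the data shown here, with no precedent for it, no step beyond the scatter is expected in this assay, and the estimate stays near compound 2 at 24000 nM. The expected step is a 1.2-fold lower number from compound 2 to compound 4 (0.08 log units; within the scatter). Compound 4 is estimated at 20000 nM, with an expected range from 8000 nM to 60000 nM.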

Compound 4, half-maximal inhibitory concentration: 310 nM
Beside the measured number, compound 4's estimate is 65-fold (1.81 log units) above it; measured number outside the range, below it.
By their numbers in this assay, from the lowest: compound 4; then compounds 3 and 2 (each within the scatter of the next). At a limit, above all of these: compound 1.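

Within the data shown here, the chain on the ring nitrogen now proves to be a highly sensitive place, which the earlier compounds could not show, as all of their steps changed only the phenyl group on the oxygen. Methyl in place of hydrogen on a saturated chain carbon, three bonds along the chain from an amide-type nitrogen in a ring, adds just 1 carbon, yet in this assay it gives a 77-fold lower number from compound 2 to compound 4 (1.89 log units; beyond the scatter), whereas the change from 3-fluorophenyl to 4-chlorophenyl gives only a 1.3-fold lower number from compound 2 to compound 3 (0.12 log units; within the scatter). Nothing measured here accounts for a step of this size.

Going by these compounds, what a pentyl chain, a longer chain still, or a chain ending in an amine would give stays open, so it cannot be said whether butyl is a peak or one point on a continuing trend. Also open is whether propyl to butyl gives a step of similar size with 4-chlorophenyl or 2-methylphenyl on the oxygen, as the pair with 3-fluorophenyl is the only one shown.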